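Trifluoromethyl in place of hydrogen on compound 3

The source may hold more compounds than are shown below. What is called first, only, known or untested is meant among the compounds shown, and "the series" means these compounds.

In a functional assay on A549 cells (Homo sapiens) for antiproliferative activity, read by MTT assay, with a stated time of 72 h (a lower number here means a stronger inhibitor, a higher number a weaker inhibitor), compound 3 (`CCn1cc(C(=O)O)c(=O)c2cc(F)c(N3CCN(C(=N)NS(=O)(=O)c4ccccc4)CC3)cc21`) gives 71 nM as its value. Compound 1 (`CCn1cc(C(=O)O)c(=O)c2cc(F)c(N3CCN(C(=N)NS(=O)(=O)c4cccc(Cl)c4)CC3)cc21`) gives 71 nM and compound 2 (`CCn1cc(C(=O)O)c(=O)c2cc(F)c(N3CCN(C(=N)NS(=O)(=O)c4ccccc4Cl)CC3)cc21`) gives 71 nM in the same test, so compound 3 stands level with both.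

Compound 4 (`CCn1cc(C(=O)O)c(=O)c2cc(F)c(N3CCN(C(=N)NS(=O)(=O)c4ccccc4C(F)(F)F)CC3)cc21`) has trifluoromethyl in place of hydrogen on an aromatic carbon, ortho to a large group (trifluoromethyl in place of hydrogen on an aromatic carbon). Within the data shown here, three measured steps bear on this change: the switch of 2-chlorophenyl for 3-chlorophenyl (no change at the digits printed from compound 1 to compound 2 (within the scatter)), and the two replacements of chloro by hydrogen (no change at the digits printed from compound 1 to compound 3 (within the scatter); no change at the digits printed from compound 2 to compound 3 (within the scatter)). The last is the closest parallel, since the name 2-chlorophenyl matches 2-(trifluoromethyl)phenyl. Among the measured compounds shown here, none of these steps left the scatter, yet no measured compound carries trifluoromethyl, so that group remains untested. No step beyond the scatter is expected in this assay, in either direction, and the estimated change is small (a 1.1-fold higher number from compound 3 to compound 4 (0.02 log units; within the scatter)). The estimate for compound 4 is 75 nM with an expected range from 35 nM to 170 nM around it.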

Compound 4, half-maximal inhibitory concentration: 71 nM
For compound 4 the middle estimate is 1.1-fold (0.02 log units) above the measured one; the range from low to high includes it.
By their numbers in this assay, from the lowest: compounds 1, 2, 3 and 4 (each within the scatter of the next).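

In this assay, among these compounds, trifluoromethyl in place of hydrogen on an aromatic carbon gives no change at the digits printed from compound 3 to compound 4 (within the scatter), the first reading for a group larger than chloro at this place. Trifluoromethyl in place of chloro gives no change at the digits printed from compound 2 to compound 4 (within the scatter) and 2-(trifluoromethyl)phenyl in place of 3-chlorophenyl on the sulfonyl sulfur gives no change at the digits printed from compound 1 to compound 4 (within the scatter), so all four compounds now read alike, and a change at this place has still not moved the value outside the scatter. Nothing at hand accounts for this flat result.

The compounds shown carry only hydrogen, chloro or trifluoromethyl on this ring, so it remains open whether an amine or a carboxylic acid at this aromatic carbon would shift the value. From the compounds shown here alone, it also remains open whether any replacement on the ring can shift it at all.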